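Ethoxycarbonyl on the sulfur-bound chain carbon: compound 4

The source may hold more compounds than are shown below. What is called first, only, known or untested is meant among the compounds shown, and "the series" means these compounds.

Measured so far:
Compound 1 `C=CCSc1nnc(CC)n1N1C(=O)c2ccccc2C1=O` — in a functional assay on MKN-45 cells (Homo sapiens) for cytotoxicity, read by MTT assay, with a stated time of 48 h (a lower number here means a stronger inhibitor, a higher number a weaker inhibitor), compound 1 gives only a limit of the assay, > 200000 nM.
Compound 2 `CCc1nnc(SCc2ccccc2)n1N1C(=O)c2ccccc2C1=O` — in this assay compound 2 gives only a limit of the assay, > 200000 nM.
Compound 3 `CCc1nnc(SC)n1N1C(=O)c2ccccc2C1=O` — in this assay compound 3 gives only a limit of the assay, > 200000 nM.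

Compound 3 therefore stands nowhere readable on the numbers shown: all three values sit at the same limit, (the limit of > 200000 nM in this assay, at which 3 of the 3 values shown sit). The steps among them, a step that the two limits leave unreadable from compound 1 to compound 2, a step that the two limits leave unreadable from compound 1 to compound 3 and a step that the two limits leave unreadable from compound 2 to compound 3, are all unreadable, so neither vinyl, phenyl nor hydrogen on the saturated chain carbon bound to the sulfur has shown any readable effect.

Compound 4 `CCOC(=O)CSc1nnc(CC)n1N1C(=O)c2ccccc2C1=O` differs from compound 3 by ethoxycarbonyl in place of hydrogen on a saturated chain carbon bound to a sulfur. Within the data shown here, no measured step bears on this change in a readable way; the only evidence is that three variations at the same place all remain at the limit. No step beyond the scatter is expected from compound 3 to compound 4, and the estimate a number no higher from compound 3 to compound 4 (the limit leaves the size open) reflects that. Compound 4 is expected in this assay at 200000 nM, between 80000 nM and 400000 nM, most likely reported again as a limit.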

Compound 4, half-maximal inhibitory concentration: > 200000 nM
Compound 4: only a limit was reported (the forecaster's own chance of this, stated with the estimate: 80%); the middle value lies on the limit itself.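

In this assay compound 4 gives only a limit, > 200000 nM. Among these compounds, no step from compound 1, compound 2 or compound 3 to compound 4 can be read: the limit of > 200000 nM in this assay, at which 4 of the 4 values shown sit. On these data alone, whether any group on a saturated chain carbon bound to a sulfur gives a readable value in this assay remains open.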